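The compounds below may be only part of what the source reports. "The series", "measured", "known", "first", "only" and "open" are said of these compounds alone.

Measured compounds:
compound 1 `Clc1ccc(OCc2nc3ccccc3n2CCC2CCCCN2)cc1` gives 7860 nM
compound 2 `Clc1ccc(OCc2nc3c(OCCCC4CCNCC4)cccc3n2CCCC2CCCNC2)cc1` gives 152 nM

In an assay on isolated protein for binding affinity to Neuropeptide Y receptor type 1 (Homo sapiens) (a lower number here means a stronger inhibitor, a higher number a weaker inhibitor), compound 2 holds the lowest number of the two; compound 1 sits far from it, beyond the scatter. Compound 3 `Clc1ccc(OCc2nc3c(OCCCN4CCCCC4)cccc3n2CCCC2CCCNC2)cc1` is not yet measured. It keeps the same atoms as compound 2, joined differently: piperidin-1-yl in place of piperidin-4-yl on a saturated chain carbon, three bonds along the chain from an oxygen on an aromatic ring. Piperidin-1-yl in place of piperidin-4-yl on that chain carbon is a small rearrangement, and no comparable step is available among the measured pair, so a step of modest size is expected, either way, likely within or near the scatter. For compound 3 the estimated step of a 1.4-fold higher number from compound 2 to compound 3 (0.16 log units; within the scatter) is small. Compound 3 is expected at 220 nM, within 60 nM to 800 nM.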

Compound 3, inhibition constant: 1.7 nM
Beside the measured number, compound 3's estimate is 130-fold (2.11 log units) above it; measured number below the stated range.
By their numbers in this assay, from the lowest: compound 3; then compound 2; then compound 1.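

In this assay, 3-(piperidin-1-yl)propyl in place of 3-(piperidin-4-yl)propyl brings an 89-fold lower number from compound 2 to compound 3 (1.95 log units; beyond the scatter) and shows that this position is highly sensitive to how the ring is joined to the chain, even with the atoms unchanged. The change also takes the group from 1 hydrogen-bond donor to 0, and this single pair cannot separate that difference from the change in attachment. No available evidence bears on the origin of this step. Going by these compounds, whether pyrrolidin-1-yl, morpholin-4-yl or an open-chain diethylamino group would hold this level remains open. A shorter or longer chain carrying the piperidin-1-yl ring is equally untested here.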